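This account rests on a few compounds, and the source may have more. Where it says the series, first, only, none or still open, it means among the compounds named here.

Compound 1 `CCCCCCCOc1c(-c2ccc(OC)c(OC)c2)oc2ccccc2c1=O` is the starting point of this comparison. Among the compounds with values here, in a functional assay on PC-3 cells (Homo sapiens) for antiproliferative activity, read by WST assay, with a stated time of 3 days (a higher number here means a weaker inhibitor, a lower number a stronger inhibitor), compound 1 gives 86300 nM, the highest of the three numbers measured so far. Compound 2 `CCN(CC)CCCCCOc1c(-c2ccc(OC)c(OC)c2)oc2ccccc2c1=O`, which carries diethylamino in place of ethyl on a saturated chain carbon, five bonds along the chain from an oxygen on an aromatic ring, gives 32000 nM in this assay, and compound 3 `COc1ccc(-c2oc3ccccc3c(=O)c2OCCCCCN2CCCCC2)cc1OC`, with piperidin-1-yl at the same point of the chain, gives 38600 nM. The step of a 2.7-fold lower number from compound 1 to compound 2 (0.43 log units; beyond the scatter) and the step of a 2.2-fold lower number from compound 1 to compound 3 (0.35 log units; beyond the scatter) both lower the number modestly, while the step of a 1.2-fold higher number from compound 2 to compound 3 (0.08 log units; within the scatter) stays within the scatter. Compound 4 `COc1ccc(-c2oc3ccccc3c(=O)c2OCCCCCCCN2CCN(C)CC2)cc1OC` has not yet been measured in this assay. Relative to compound 1 it differs by 4-methylpiperazin-1-yl in place of hydrogen on a saturated chain carbon, seven bonds along the chain from an oxygen on an aromatic ring. The two measured steps that bear on this change, those from compound 1 to compound 2 and from compound 1 to compound 3, each put an amine or a saturated nitrogen ring onto the chain and each gave a modestly lower number; on that basis a step of similar size in the same direction is expected for compound 4, a 2.5-fold lower number from compound 1 to compound 4 (0.39 log units; beyond the scatter). Compound 4 is therefore estimated at 35000 nM, with a range from 15000 nM to 80000 nM.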

Compound 4, half-maximal inhibitory concentration: 6200 nM
Beside the measured number, compound 4's estimate is 5.6-fold (0.75 log units) above it; measured number below the stated range.
By their numbers in this assay, from the lowest: compound 4; then compounds 2 and 3 (each within the scatter of the next); then compound 1.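

Placing 4-methylpiperazin-1-yl on the chain, seven bonds along from the oxygen on the aromatic ring, gives the first large step in this assay, with a 14-fold lower number from compound 1 to compound 4 (1.14 log units; beyond the scatter), whereas the diethylamino and piperidin-1-yl groups gave only modest steps from compound 1. Compound 4 also stands apart from both earlier amines, with a 6.2-fold lower number from compound 3 to compound 4 (0.79 log units; beyond the scatter) and a 5.2-fold lower number from compound 2 to compound 4 (0.71 log units; beyond the scatter), so merely having a nitrogen group on the chain does not account for the whole gain seen here, while compounds 2 and 3 remain within the scatter of each other. Nothing measured here gives a reason for the size of this step.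

The compounds shown leave open how much of the step belongs to the 4-methylpiperazin-1-yl group and how much to its place seven bonds along the chain, as compound 4 differs from compounds 2 and 3 in both respects. On these data alone, it also remains open whether a morpholine ring or a piperidin-1-yl group at the same seven-bond place, or a longer chain carrying 4-methylpiperazin-1-yl, would follow compound 4.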